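The source may hold more compounds than are shown below. What is called first, only, known or untested is meant among the compounds shown, and "the series" means these compounds.

Compound 1 `O/N=C(\CCN1CCN(c2ccccn2)CC1)c1cccc(Cl)c1` gives 11.9 nM in a functional assay on HEK293 cells with D(4) dopamine receptor (Homo sapiens) as the target, read by FLIPR; on this read-out higher numbers stand for an effect only at larger amounts of compound and lower numbers for an effect already at smaller amounts.
Compound 2 `N#Cc1cccc(/C(CCN2CCN(c3ccccn3)CC2)=N/O)c1` gives 13.1 nM.
Compound 3 `CCO/N=C(\CCN1CCN(c2ccccc2)CC1)c1ccccc1` gives 109 nM.

Compound 3 stands highest of the three numbers in this assay; the nearest is compound 2 and the furthest compound 1, both gaps beyond the scatter. Compound 4 `CCO/N=C(\CCN1CCN(c2ccccc2OC)CC1)c1ccccc1` differs from compound 3 by methoxy in place of hydrogen on an aromatic carbon. Among the compounds with values here, the single measured step, a 1.1-fold higher number from compound 1 to compound 2 (0.04 log units; within the scatter), concerns a different part of the molecule and does not bear on this change; no measured pair covers a substituent on the aryl piperazine ring. With nothing to anchor the direction, compound 4 is expected to stay near compound 3, and the uncertainty is wide. For compound 4 the expected step is a 2.0-fold lower number from compound 3 to compound 4 (0.30 log units; within the scatter). The estimate for compound 4 is 55 nM, with a range from 12 nM to 250 nM.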

Compound 4, half-maximal effective concentration: 338 nM
Compound 4: middle estimate off by 6.1-fold (0.79 log units), on the low side, and the stated range ends below it.
By their numbers in this assay, from the lowest: compounds 1 and 2 (each within the scatter of the next); then compound 3; then compound 4.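

Methoxy in place of hydrogen on an aromatic carbon, ortho to a large group, gives the first reading for a change on this ring in this assay (a 3.1-fold higher number from compound 3 to compound 4 (0.49 log units; beyond the scatter)). At this place, phenyl to 2-methoxyphenyl therefore shifts the effect to larger amounts of compound, by a modest step beyond the scatter. Nothing at hand accounts for the shift.

From the compounds shown here alone, whether fluoro or ethoxy at the same place would give a similar step remains open. So does whether methoxy would act the same way on the core of compound 1.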